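Swapping ethyl for difluoromethyl on a deubiquitinase inhibitor

The source may report more compounds than this note shows. Statements on the series, on what has been measured and on what is new or still open speak of the compounds shown alone.

Measured compounds:
compound 1, `FC(F)(F)c1ccccc1-c1nc(NCC#Cc2cccnc2)c2ccccc2n1`, 8900 nM
compound 2, `CCc1ccccc1-c1nc(NCc2ccc(-c3cccnc3)cc2)c2ccccc2n1`, 780 nM

Within the data shown here, in an assay on a protein complex for inhibition of ubiquitin carboxyl-terminal hydrolase 1/WD repeat-containing protein 48 (Homo sapiens), read by fluorescence (a higher number here means a weaker inhibitor, a lower number a stronger inhibitor), compound 2 gives 780 nM, the lower of the two numbers so far. Its nearest neighbour is compound 1, whose 8900 nM is a higher number, a gap that lies beyond the scatter of repeated measurements. The two compounds differ in more than one place, so nothing can be said about which of their differences carries that gap.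

Compound 3, `FC(F)c1ccccc1-c1nc(NCc2ccc(-c3cccnc3)cc2)c2ccccc2n1`, has not yet been measured. It departs from compound 2 in a single change: difluoromethyl in place of ethyl on an aromatic carbon. The group that leaves and the group that enters are of about the same size, neither carries a ring, and neither adds a hydrogen-bond donor or acceptor to the count.

Among the measured compounds shown here, with no measured pair showing this change on its own, the expected step is small: the estimated 1.5-fold higher number from compound 2 to compound 3 (0.19 log units; within the scatter) is a modest rise in the number, close to the edge of the scatter. Compound 3 is therefore expected to give about 1200 nM in this assay, within a range of 400 nM to 4000 nM.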

Compound 3, half-maximal inhibitory concentration: 1400 nM
The estimate for compound 3 lay 1.2-fold (0.07 log units) below the measured number, within the range that was stated.
By their numbers in this assay, from the lowest: compounds 2 and 3 (each within the scatter of the next); then compound 1.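

Among these compounds, this is the first pair that differs in one place only, so the change can now be read on its own. In this assay, difluoromethyl in place of ethyl gives a 1.8-fold higher number from compound 2 to compound 3 (0.25 log units; within the scatter), on an aromatic carbon ortho to a large group. At this place, then, the measurement cannot tell the 2-ethylphenyl group from the 2-(difluoromethyl)phenyl group, even though two fluorine atoms enter with the change.

Still open, going by these compounds, is whether this place tolerates groups of a different kind, such as an amine, a carboxylic acid or a longer chain, and whether the same swap would give a similar step on a compound with a different side chain, such as that of compound 1. The reason for the result is open too, as no measurement offers an explanation for it.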